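Phenyl for Thiophene on a Shared Nucleoside Core

The source may report more compounds than this note shows. Statements on the series, on what has been measured and on what is new or still open speak of the compounds shown alone.

compound 1 `Nc1nc(N)c2c(-c3cc4ccccc4o3)cn([C@@H]3O[C@H](CO)[C@@H](O)[C@H]3O)c2n1`: > 20000 nM
compound 2 `Cc1ncnc2c1c(-c1cccs1)cn2[C@@H]1O[C@H](CO)[C@@H](O)[C@H]1O`: > 20000 nM
compound 3 `COc1ncnc2c1c(-c1cccs1)cn2[C@@H]1O[C@H](CO)[C@@H](O)[C@H]1O`: 80 nM

In a functional assay on HCT-116 cells (Homo sapiens), read by MTT assay, with a stated time of 72 h (a lower number here means a stronger inhibitor, a higher number a weaker inhibitor), compound 1 gives > 20000 nM, which is a limit of the assay and not a number. Compound 2 gives > 20000 nM, likewise a limit. Compound 3 gives 80 nM, the only number shown in this assay. Among the measured compounds shown here, the single measured step, an at least 250-fold lower number from compound 2 to compound 3 (2.39 log units; beyond the scatter), comes from methoxy in place of methyl on an aromatic carbon, and the limit of > 20000 nM in this assay, at which 2 of the 3 values shown sit, marks where the two weaker compounds sit.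

Compound 4 `COc1ncnc2c1c(-c1ccccc1)cn2[C@@H]1O[C@H](CO)[C@@H](O)[C@H]1O` differs from compound 3 by phenyl in place of thiophen-2-yl on an aromatic carbon. None of the measured steps bears on this change: the only step shown concerns the methoxy group and leaves the five-membered aromatic ring untouched, so it gives no guide to the size or direction of the new step. With no comparable change among the measured compounds, the expectation is a step in this assay that stays within the scatter, or at most a small one in either direction.

Compound 4 is therefore expected to give about 120 nM in this assay, estimated between 35 nM and 450 nM. The step of a 1.5-fold higher number from compound 3 to compound 4 (0.18 log units; within the scatter) is expected.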

Compound 4, half-maximal inhibitory concentration: > 20000 nM
Compound 4: only a limit was reported; the forecaster's own chance of this, stated with the estimate: 10%; middle value at least 160-fold (2.22 log units) from the limit.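

In this assay, the group on the aromatic carbon two ring bonds from the ring nitrogen turns out to matter as much as the methoxy group: phenyl in place of thiophen-2-yl gives an at least 250-fold higher number from compound 3 to compound 4 (2.39 log units; beyond the scatter), a step of the same printed size as an at least 250-fold lower number from compound 2 to compound 3 (2.39 log units; beyond the scatter). The earlier compounds shown here showed only that exchanging methoxy for methyl counts when thiophen-2-yl is present, whereas compound 4 keeps the methoxy group and still gives > 20000 nM, which is a limit of the assay and not a number. Among the compounds shown, the methoxy group does not suffice alone, and only compound 3, which pairs it with thiophen-2-yl, escapes the limit that holds the others: the limit of > 20000 nM in this assay, at which 3 of the 4 values shown sit.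

The compounds shown leave open whether another five-membered ring at this position, such as furan-2-yl or thiophen-3-yl, would keep a value near that of compound 3, or whether a six-membered ring with a ring nitrogen, such as a pyridyl group, would behave like phenyl. They also leave open whether an ethoxy group or an amine could stand in for the methoxy group while thiophen-2-yl stays in place.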